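Swapping the Side Group on Compound 3

The source may report more compounds than this note shows. Statements on the series, on what has been measured and on what is new or still open speak of the compounds shown alone.

Of the compounds shown here, three have been tested in an assay on isolated protein for inhibition of RAC-alpha serine/threonine-protein kinase (Homo sapiens), read by HTRF, tested at 10 uM; a lower number here means less inhibition, a higher number more inhibition at the concentration tested (going by the name of the read-out). Compound 1 `Cc1cccc(N(C)c2cc(Nc3cccc(C(=O)N(CC(C)C)CC(C)C)c3)ncn2)c1` gives 0%, compound 2 `Cc1cccc(Oc2ccnc(N3CCC[C@H]3C(=O)NCCCn3ccnc3)n2)c1` gives 0%, and compound 3 `Clc1ccc2sc(CN3CCN(c4ncnc5c4CN(Cc4ccccc4)CC5)CC3)cc2c1` gives 2%. Compound 3 holds the highest of the three numbers, yet compound 1 and compound 2 both sit within the scatter of it, so no order can be read among them. Compound 4 `O=C(CN1CCN(c2ncnc3c2CN(Cc2ccccc2)CC3)CC1)Nc1cc(F)ccc1F` has not been measured. It differs from compound 3 in one place: (2,5-difluorophenyl)carbamoyl in place of 5-chloro-1-benzothiophen-2-yl on a saturated chain carbon bound to an amine nitrogen in a ring. For the measured compounds named here, no step between measured compounds exists, so the expectation rests on the three near-zero numbers alone. Because compound 3 gives 2%, the expected step is a number 1 percentage points higher from compound 3 to compound 4 (within the scatter), none beyond the scatter. Compound 4 is expected to give 3% in this assay, within a range from -8% to 15%.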

Compound 4, a percentage reported as inhibition, at one concentration (the size of the read-out at that concentration, not a potency): 0%
Compound 4: the middle estimate sits 3 percentage points above what was measured, and the stated range covers the measured number.
By their numbers in this assay, from the lowest: compounds 1, 2, 4 and 3 (each within the scatter of the next).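

For the compounds shown here, putting (2,5-difluorophenyl)carbamoyl in place of 5-chloro-1-benzothiophen-2-yl gives a number 2 percentage points lower from compound 3 to compound 4 (within the scatter) in this assay and provides the first one-place comparison in the set. At this position, a group with one aromatic ring and an amide hydrogen and a group with two aromatic rings and a chlorine cannot be told apart, and both numbers lie near zero. No measurement bears on this result. On these data alone, whether an amine or a carboxylic acid on this saturated chain carbon would give a number clear of the scatter remains open, as does whether any group here can do so on the shared core.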